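Ethoxycarbonyl in Place of Hydroxymethyl: an Unmeasured Analogue

A few compounds are considered here, and "the series" means these few. Any claim that something is new, unique, unknown or untested is made for them only; others in the source may bear on it.

Compound 1 `CCOC(=O)[C@@]1(C(=O)Nc2ccccc2)C[C@@H]1c1cc(OC)c(OC)c(OC)c1`: in a functional assay on K562 cells (Homo sapiens) for cytotoxicity, read by MTT assay, with a stated time of 48 h (on this read-out higher numbers stand for weaker inhibition and lower numbers for stronger inhibition), compound 1 gives > 100000 nM, which is a limit of the assay and not a number.
Compound 2 `COc1cc([C@H]2C[C@@]2(CO)C(=O)Nc2ccccc2)cc(OC)c1OC`: compound 2 gives > 100000 nM, also a limit.
Compound 3 `COc1cc([C@H]2C[C@]2(CO)C(=O)Nc2ccccc2Cl)cc(OC)c1OC`: compound 3 gives > 100000 nM, again a limit.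

Compound 4 `CCOC(=O)[C@]1(C(=O)Nc2ccccc2Cl)C[C@@H]1c1cc(OC)c(OC)c(OC)c1` has not yet been measured. It differs from compound 3 by ethoxycarbonyl in place of hydroxymethyl on a saturated ring carbon. The same change, (ethoxycarbonyl in place of hydroxymethyl on a saturated ring carbon), joins compound 2 to compound 1, and that step, a step that the two limits leave unreadable from compound 2 to compound 1, cannot be read because of the limit of > 100000 nM in this assay, at which 3 of the 3 values shown sit. The difference between the cores of compound 2 and compound 3 is not broken down here. Within the data shown here, the step from compound 3 to compound 4 in this assay is expected to be a step that the limit leaves unreadable from compound 3 to compound 4, since the only measured instance of this change gave no readable size. Compound 4 is accordingly estimated at 150000 nM, between 50000 nM and 500000 nM, most probably reported once more only as a limit.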

Compound 4, half-maximal inhibitory concentration: 19500 nM
Compound 4: middle estimate off by 7.7-fold (0.89 log units), on the high side; the whole stated range lies above it.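

On the core of compound 3, ethoxycarbonyl in place of hydroxymethyl gives, in this assay, an at least 5.1-fold lower number from compound 3 to compound 4 (0.70 log units; beyond the scatter), and this size is only a bound. The same change on the core of compound 2 cannot be read, because both of its ends sit at a limit: the limit of > 100000 nM in this assay, at which 3 of the 4 values shown sit. The change therefore has a readable size on one core only, and the data show neither that it carries over to the core of compound 2 nor that it fails to.

On these data alone, what a carboxylic acid, an amine or a longer chain in place of ethoxycarbonyl on that saturated ring carbon would give stays open. Also open, as far as these compounds go, is how much the difference between the cores of compound 2 and compound 3 contributes.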